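Thiazolyl amides: removing the chloro and liver microsome half-life

The source may report more compounds than this note shows. Statements on the series, on what has been measured and on what is new or still open speak of the compounds shown alone.

Measured so far:
- compound 1, `Cc1cnc(NC(=O)CCCOc2cncc(Cl)c2)s1`, 0.333 h
- compound 2, `N#Cc1cnc(NC(=O)CCCOc2cccc(Cl)c2)s1`, 0.25 h

In an ADME assay on microsomes from liver (Homo sapiens) for metabolic stability, read by LC-MS, using NADPH, tested at 1 uM (on this read-out higher numbers stand for a longer-lived compound and lower numbers for a shorter-lived compound), compound 2 gives 0.25 h, the lowest of the two numbers; compound 1 gives 0.333 h, which lies within the scatter of that value. Compound 3, `N#Cc1cnc(NC(=O)CCCOc2ccccc2)s1`, differs from compound 2 by hydrogen in place of chloro on an aromatic carbon. Among the measured compounds shown here, no measured pair shows this change, so there is no step to lean on. The expectation is a step of a 1.1-fold lower number from compound 2 to compound 3 (0.06 log units; within the scatter), none beyond the scatter. Compound 3 is estimated at 0.22 h, within 0.1 h to 0.5 h.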

Compound 3, half-life in the Homo sapiens assay: 0.15 h
Compound 3: middle estimate off by 1.5-fold (0.17 log units), on the high side; the measured number falls inside the stated range.
By their numbers in the Homo sapiens assay, from the lowest: compounds 3, 2 and 1 (each within the scatter of the next, the first and the last beyond it).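

Among the compounds shown here, the first measured pair for hydrogen in place of chloro on an aromatic carbon gives, in the Homo sapiens assay, a 1.7-fold lower number from compound 2 to compound 3 (0.22 log units; within the scatter), so this change stays within the scatter at this position. In a physicochemical assay for solubility, read by nephelometry, at pH 2 (on this read-out lower numbers stand for lower solubility and higher numbers for higher solubility), compound 2 gives < 1600 nM, which is a limit of the assay and not a number: the limit of < 1600 nM in the physicochemical assay, at which 1 of the 2 values shown sits. In the physicochemical assay compound 3 gives 1100 nM, and the step between the two cannot be read.

Going by these compounds, whether a methoxy group or fluoro in the same place would shift the half-life beyond the scatter stays open. So does whether the same change on the core of compound 1 gives a similar step.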